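Aryl piperazine succinimide amides: ortho trifluoromethyl analogue

The compounds below may be only part of what the source reports. "The series", "measured", "known", "first", "only" and "open" are said of these compounds alone.

Measured compounds in a functional assay on the whole organism (strain Swiss) with Mus musculus as the target, in the maximal electroshock model, with a stated time of 0.5 h, at a dose of 300 mg/kg by the intraperitoneal route; a lower number here means a weaker effect, a higher number a stronger effect of the compound at the dose given:
compound 1, `CCC(C(=O)N1CCN(c2ccccc2Cl)CC1)N1C(=O)CCC1=O`, 25%
compound 2, `CCC(C(=O)N1CCN(c2cccc(F)c2)CC1)N1C(=O)CCC1=O`, 100%
compound 3, `CCC(C(=O)N1CCN(c2ccc(F)cc2)CC1)N1C(=O)CCC1=O`, 25%

Compound 1 stands, together with compound 3, at the lowest of the three numbers; the two differ by no change at the digits printed from compound 1 to compound 3 (within the scatter). Compound 2 is the only one clearly apart: a number 75 percentage points higher from compound 1 to compound 2 (beyond the scatter), and in the other direction a number 75 percentage points lower from compound 2 to compound 3 (beyond the scatter). The series thus shows that moving a single halogen around the aryl ring can shift the read-out strongly, while the change of compound 1 to compound 3 leaves it where it was.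

Compound 4, `CCC(C(=O)N1CCN(c2ccccc2C(F)(F)F)CC1)N1C(=O)CCC1=O`, is not yet measured. It differs from compound 1 in one place: trifluoromethyl in place of chloro on an aromatic carbon. Among the compounds with values here, none of the measured steps exchanges chloro for trifluoromethyl, and none keeps the substituent at the position ortho to a large group, so there is no direct precedent. Within the data shown here, the nearest guide is that compound 1 sits at the floor of the series together with compound 3, and the one large change seen required a different position rather than a different group. For compound 4 the expected step is therefore a number 5 percentage points higher from compound 1 to compound 4 (within the scatter), with considerable uncertainty. The estimate for compound 4 in this assay is 30%, in the range 0% to 75%.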

Compound 4, a percentage reported as activity, at one dose (the size of the read-out at that dose, not a potency): 25%
Compound 4: the middle estimate sits 5 percentage points above what was measured; low and high end bracket the measured number.
By their numbers in this assay, from the lowest: compounds 1, 3 and 4 (each within the scatter of the next); then compound 2.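

In this assay, trifluoromethyl in place of chloro on an aromatic carbon, ortho to a large group, gives no change at the digits printed from compound 1 to compound 4 (within the scatter). Within the data shown here, this is the first step that exchanges the group while keeping its place, and at this position the read-out does not separate chloro from trifluoromethyl. Among these compounds, the only steps beyond the scatter involving compound 1 or compound 3 lead to or from compound 2, as in a number 75 percentage points higher from compound 1 to compound 2 (beyond the scatter), which alters both the group and its place. Nothing at hand bears on why the two groups read alike.

Going by these compounds, it remains open whether trifluoromethyl in the place of the fluoro of compound 2 would leave the read-out of compound 2 at 100%. On these data alone, it is equally open whether an amine or a methoxy group on the aromatic carbon of compound 1 would leave the read-out where it stands.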